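This account rests on a few compounds, and the source may have more. Where it says the series, first, only, none or still open, it means among the compounds named here.

Measured compounds:
compound 1, `Fc1cccc(F)c1C#Cc1cnc2ccccc2c1`: 41.7%
compound 2, `Fc1cccc(F)c1C#Cc1cc2ccccc2nc1Cl`: 28.4%

Going by the values given here, in a functional assay on LS174T cells (Homo sapiens) for inhibition, with a stated time of 4 days, tested at 1 uM (on this read-out higher numbers stand for a stronger effect at the one concentration tested and lower numbers for a weaker effect), compound 1 stands highest of the two numbers; the one step seen, a number 13.3 percentage points lower from compound 1 to compound 2 (beyond the scatter), is a change at a different place on the core. Compound 3, `Fc1ccc2cc(C#Cc3c(F)cccc3F)cnc2c1`, differs from compound 1 by fluoro in place of hydrogen on an aromatic carbon. Among the compounds with values here, no measured step concerns this position or this group, so nothing known points in either direction. For compound 3 the expected change is a number 1.7 percentage points lower from compound 1 to compound 3 (within the scatter), within the scatter. Compound 3 is therefore estimated at 40%, between 25% and 55%.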

Compound 3, a percentage reported as inhibition, at one concentration (the size of the read-out at that concentration, not a potency): 69.4%
Compound 3: the middle estimate sits 29.4 percentage points below what was measured; the measured number lies above the stated range.
By their numbers in this assay, from the lowest: compound 2; then compound 1; then compound 3.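

In this assay, fluoro in place of hydrogen on the carbon-only aromatic ring of the shared core gives a number 27.7 percentage points higher from compound 1 to compound 3 (beyond the scatter). Going by these compounds alone, a change of just one atom at this position can therefore raise the read-out clearly, whereas the only earlier step, chloro at a different place on the core, lowered it. Nothing measured here offers a reason for the rise. From the compounds shown here alone, whether chloro, methoxy or an amine at this same position would also raise the read-out stays open. So does whether fluoro on the other carbons of this ring would do so.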